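Aryl versus tert-butyl at the core of a pyridine nitrile series

This account rests on a few compounds, and the source may have more. Where it says the series, first, only, none or still open, it means among the compounds named here.

Measured compounds:
compound 1, `COc1nc(-c2ccccc2)cc(-c2ccc(F)cc2)c1C#N`, 25 nM
compound 2, `COc1nc(C(C)(C)C)cc(-c2ccc(F)cc2)c1C#N`, 153 nM

The two compounds share one core and differ only in the group on the aromatic carbon next to the ring nitrogen. In an assay on isolated protein for inhibition of sulfide:quinone oxidoreductase, mitochondrial (Homo sapiens) (on this read-out higher numbers stand for weaker inhibition and lower numbers for stronger inhibition), compound 1 gives 25 nM, and compound 2 gives 153 nM. The single step shown is a 6.1-fold higher number from compound 1 to compound 2 (0.79 log units; beyond the scatter); on this read-out compound 2 stands at the higher of the two numbers, with compound 1 as its only neighbour.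

Compound 3, `COc1nc(-c2ccncc2)cc(-c2ccc(F)cc2)c1C#N`, is not yet measured. Its change from compound 2 is pyridin-4-yl in place of tert-butyl on an aromatic carbon. Among the measured compounds shown here, the one measured step that bears on it is the reverse of the phenyl-to-tert-butyl step, a 6.1-fold higher number from compound 1 to compound 2 (0.79 log units; beyond the scatter), since an aromatic six-membered ring again enters where tert-butyl leaves. Nothing measured speaks to the ring nitrogen itself. The expected step is therefore a drop back toward compound 1, with some allowance for the untested nitrogen: compound 3 is estimated at a 3.8-fold lower number from compound 2 to compound 3 (0.58 log units; beyond the scatter). In this assay compound 3 is expected near 40 nM, within 12 nM to 130 nM.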

Compound 3, half-maximal inhibitory concentration: 17400 nM
Beside the measured number, compound 3's estimate is 440-fold (2.64 log units) below it, and the stated range ends below it.
By their numbers in this assay, from the lowest: compound 1; then compound 2; then compound 3.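

In this assay, the change to pyridin-4-yl gives the largest step in the series, a 110-fold higher number from compound 2 to compound 3 (2.06 log units; beyond the scatter), and the comparison with the aryl parent is larger still, a 700-fold higher number from compound 1 to compound 3 (2.84 log units; beyond the scatter). Compound 1 and compound 3 differ only by the ring nitrogen of pyridin-4-yl, so this position clearly does not accept every six-membered aromatic ring alike, and a ring at this position is not enough for a low number. Compound 2, whose tert-butyl has no ring, falls between the two aromatic compounds in the order of numbers, and no measurement shown gives a reason for the loss seen with compound 3.

The compounds shown leave open whether the loss is tied to where the nitrogen sits in the ring, which pyridin-3-yl would test against pyridin-4-yl and phenyl. They also leave open how far phenyl can be changed at this position without such a loss, for example by a saturated cyclohexyl ring or by a phenyl ring carrying a methoxy group or an amine.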